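The source may hold more compounds than are shown below. What is called first, only, known or untested is meant among the compounds shown, and "the series" means these compounds.

Three compounds have been measured in a functional assay on the whole organism (strain albino) with Mus musculus as the target, at a dose of 100 mg/kg by the intraperitoneal route; on this read-out lower numbers stand for less inhibition and higher numbers for more inhibition at the one dose given (going by the name of the read-out):

Compound 1, `CCc1nc2ccccc2c(=O)n1NC(=O)Nc1ccc([N+](=O)[O-])cc1`, gives 41%.
Compound 2, `CCc1ccc(NC(=O)Nn2c(-c3ccccc3)nc3ccccc3c2=O)cc1`, gives 61%.
Compound 3, `CCOc1ccc(NC(=O)Nn2c(CC)nc3ccccc3c2=O)cc1`, gives 50%.

Compound 3 stands second highest of the three numbers. Its nearest neighbour is compound 1, whose number lies within the scatter of compound 3, so the two cannot be told apart on this read-out; compound 2 lies beyond the scatter, with the higher number. Compound 4, `CCc1ccc(NC(=O)Nn2c(CC)nc3ccccc3c2=O)cc1`, has not yet been measured. It differs from compound 3 in one place: ethyl in place of ethoxy on an aromatic carbon. Going by the values given here, only one measured step changes a single group at this same place on the shared core: a number 9 percentage points higher from compound 1 to compound 3 (within the scatter), which puts ethoxy in place of nitro on an aromatic carbon and stays within the scatter. Among the compounds with values here, no measured step puts ethyl in place of ethoxy, so the most that can be drawn from the data is that one change at this place has so far moved the number by less than the scatter. Compound 2 also carries an ethyl group, but it differs from compound 4 in more than one place, so its value shows only what the whole compound does. The step of no change at the digits printed from compound 3 to compound 4 (within the scatter) is therefore expected to stay within the scatter. Compound 4 is estimated at 50%, with a range from 35% to 65%.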

Compound 4, a percentage reported as inhibition, in the whole organism at one dose (the size of the read-out at that dose, not a potency): 58%
Compound 4: the middle estimate sits 8 percentage points below what was measured, within the range that was stated.
By their numbers in this assay, from the lowest: compounds 1, 3, 4 and 2 (each within the scatter of the next, the first and the last beyond it).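

Putting ethyl in place of ethoxy, on an aromatic carbon para to a large group, gives a number 8 percentage points higher from compound 3 to compound 4 (within the scatter), so this assay cannot tell these two groups apart at this place. Going by these compounds alone, putting ethyl in place of nitro at the same place gives a number 17 percentage points higher from compound 1 to compound 4 (beyond the scatter), the first step here to pass the scatter, which shows that the choice of group at this place can register in the read-out, even though compound 3, with its ethoxy group, cannot be separated from either compound 1 or compound 4. Ethyl in place of phenyl, a change at another place on the shared core, gives a number 3 percentage points lower from compound 2 to compound 4 (within the scatter), so that swap leaves the read-out unresolved as well, and nothing in the data available here explains any of these steps.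

Among the compounds shown, only nitro, ethoxy and ethyl occupy this place, so it remains open how an amine, a carboxylic acid or a longer chain such as butyl would read there. From the compounds shown here alone, each number also comes from a single dose, so it is unknown whether the gap between the nitro and ethyl compounds would hold at other doses.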